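The compounds below may be only part of what the source reports. "The series", "measured", "known", "first", "only" and "open" are said of these compounds alone.

Compound 3 `O=C1COc2ccc(-c3ccc(O)cc3)cc2N1` carries a free amide hydrogen on its ring nitrogen, and in a functional assay on HCT-116 cells (Homo sapiens) for antiproliferative activity, read by MTT assay, with a stated time of 72 h (a higher number here means a weaker inhibitor, a lower number a stronger inhibitor), compound 3 gives only a limit, > 40000 nM. Compound 1 `COc1ccc(N2C(=O)COc3ccc(-c4cnc5ccccc5c4)cc32)cc1` also gives a limit in this assay, > 40000 nM. Compound 2 `COc1cccc(N2C(=O)COc3ccc(-c4cnc(Cl)c(NS(=O)(=O)c5ccc(F)cc5)c4)cc32)c1` gives a limit as well, > 40000 nM. Compound 3 therefore stands where every value shown sits, at the limit of > 40000 nM in this assay, at which 3 of the 3 values shown sit. Compound 4 `COc1ccc(N2C(=O)COc3ccc(-c4ccc(O)cc4)cc32)cc1` differs from compound 3 in a single place: 4-methoxyphenyl in place of hydrogen on an amide-type nitrogen in a ring. No measured step joins two of these compounds. Because compound 1 with the same group on the ring nitrogen sits at its limit > 40000 nM, the expected step of a number no higher from compound 3 to compound 4 (the limit leaves the size open) is none beyond the scatter. Compound 4 is accordingly expected to give about 40000 nM, within a range from 15000 nM to 100000 nM, most likely as a limit only.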

Compound 4, half-maximal inhibitory concentration: 26100 nM
Beside the measured number, compound 4's estimate is 1.5-fold (0.19 log units) above it, within the range that was stated.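

In this assay, placing 4-methoxyphenyl on the amide-type nitrogen in a ring gives a step of an at least 1.5-fold lower number from compound 3 to compound 4 (0.18 log units; that floor lies within the scatter). From the compounds shown here alone, this floor alone does not establish a real gain, and the full size of the step stays unknown, since compound 3 gives only a limit. Compound 4 is the only compound shown with a measured number rather than a limit: the limit of > 40000 nM in this assay, at which 3 of the 4 values shown sit.

The compounds shown leave open how a benzyl group or a short chain ending in an amine on that nitrogen would read in this assay. They also leave open whether the methoxy group of compound 4 contributes to its number, as a plain phenyl group does not appear among them.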